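Swapping a benzyl substituent on a urea-linked core

The source may report more compounds than this note shows. Statements on the series, on what has been measured and on what is new or still open speak of the compounds shown alone.

Of the compounds shown here, three have been measured in a functional assay on HT-29 cells (Homo sapiens) for inhibition, read by MTT assay, with a stated time of 48 h; a lower number here means a stronger inhibitor, a higher number a weaker inhibitor. Compound 1 `Cc1ccc(NC(=S)NC(=O)c2ccc(OCc3ccccc3Cl)cc2)cc1-c1nc2ccccc2[nH]1` gives 23700 nM in this assay. Compound 2 `O=C(NC(=S)Nc1ccc(Cl)c(-c2nc3ccccc3[nH]2)c1)c1ccc(OCc2ccc(Cl)cc2Cl)cc1` gives 6080 nM. Compound 3 `Cc1ccc(NC(=O)NC(=O)c2ccc(OCc3ccc(C(F)(F)F)cc3)cc2)cc1-c1nc2ccccc2[nH]1` gives 7830 nM, which places it second highest of the three numbers: its number sits within the scatter of compound 2, whereas compound 1 shows a higher number that lies beyond the scatter. No pair among these three differs in just one place, so no single structural change can yet be tied to a change in the number.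

Compound 4 `Cc1ccc(NC(=O)NC(=O)c2ccc(OCc3cccc(F)c3)cc2)cc1-c1nc2ccccc2[nH]1` is the next to be measured in this assay. It differs from compound 3 in one place: 3-fluorophenyl in place of 4-(trifluoromethyl)phenyl on a saturated chain carbon bound to an oxygen on an aromatic ring. With no single-change comparison among the measured compounds, the size of the step is uncertain, and the expectation is for a step from compound 3 to compound 4 of a 1.3-fold higher number from compound 3 to compound 4 (0.11 log units; within the scatter), not clearly beyond the scatter in either direction. For compound 4 the value in this assay is estimated at 10000 nM, with a range from 3500 nM to 30000 nM.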

Compound 4, half-maximal inhibitory concentration: 38200 nM
For compound 4 the middle estimate is 3.8-fold (0.58 log units) below the measured one, outside the stated range (above it).
By their numbers in this assay, from the lowest: compounds 2 and 3 (each within the scatter of the next); then compounds 1 and 4 (each within the scatter of the next).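

In this assay, among these compounds, this pair is the only single-place comparison so far, and it shows that the group on a saturated chain carbon bound to an oxygen on an aromatic ring is not a silent position: 3-fluorophenyl in place of 4-(trifluoromethyl)phenyl gives a 4.9-fold higher number from compound 3 to compound 4 (0.69 log units; beyond the scatter) and the step lies beyond the scatter. With the rest of the structure unchanged, compound 4, with the group of fewer heavy atoms, is the weaker inhibitor of the pair. Nothing available explains this shift.

The swap alters both the substituent and its place on the ring, so the two contributions cannot be separated. Going by these compounds, whether an unsubstituted phenyl, or a phenyl carrying a nitrile or a methoxy group, would give a number nearer compound 3 or compound 4 remains open.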